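The compounds below may be only part of what the source reports. "The series", "measured", "known", "first", "only" and "open" are said of these compounds alone.

Three compounds built on the same core, each carrying a long saturated chain, have been tested in a functional assay on cells (Lymphocyte, Homo sapiens), read by trypan blue exclusion, with a stated time of 16 h, tested at 0.1 uM; a higher number here means a stronger effect of the compound at the concentration tested, a lower number a weaker effect. Compound 1 `CCCCCCCCCCCCCCCCc1c(C)c(N(C)C)nc(C)c1O` gives 11%, compound 2 `CCCCCCCCCCc1c(C)c(N(C)C)nc(C)c1O` gives 19%, and compound 3 `Cc1c(N(C)C)nc(CCCCCCCCCCO)c(O)c1C` gives 20%. Compound 2 stands second of the three numbers, yet all three lie within the scatter of one another, so none of them is clearly set apart. Among the measured compounds shown here, the only step measured so far between compounds that differ in a single place, a number 8 percentage points higher from compound 1 to compound 2 (within the scatter), is small. Compound 4 `CCCCCCCCCCCCCCCCCCCc1c(C)c(N(C)C)nc(C)c1O` is the next compound to be measured; it differs from compound 2 by nonyl in place of hydrogen on a saturated chain carbon, ten or more bonds along the chain from an aromatic carbon. This change runs in the opposite direction to that single step, which bears on it directly and moved the number only within the scatter. A step of similar size is therefore expected in this assay, if anything downward, since compound 1 with its longer chain gave 11%. The expected step is a number 7 percentage points lower from compound 2 to compound 4 (within the scatter). Compound 4 is estimated at 12%, within a range from 3% to 24%.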

Compound 4, a percentage reported as activity, at one concentration (the size of the read-out at that concentration, not a potency): 8%
Estimate against measurement, compound 4: 4 percentage points above; measured number inside the range.
By their numbers in this assay, from the lowest: compounds 4, 1, 2 and 3 (each within the scatter of the next, the first and the last beyond it).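

In this assay, among the compounds shown here, nonyl in place of hydrogen on a saturated chain carbon, ten or more bonds along the chain from an aromatic carbon, gives a number 11 percentage points lower from compound 2 to compound 4 (beyond the scatter) and so is the first single change in this set to stand clear of the scatter. Propyl in place of hydrogen at the same place gives a number 3 percentage points lower from compound 1 to compound 4 (within the scatter) and so compound 1 and compound 4 cannot be told apart. Lengthening the chain therefore shows up here only over the full span from compound 2 to compound 4, and nothing available explains that step.

For the compounds shown here, still open is how a chain shorter than the one in compound 2 would read. So is how a chain carrying an amine or a carboxylic acid would read at this place.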